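The compounds below may be only part of what the source reports. "The series", "measured", "known", "first", "only" and "open" are said of these compounds alone.

Compound 2 `COC(=O)c1c(C)cccc1OC(=O)COc1cc(O)c2c(=O)cc(-c3ccccc3)oc2c1` gives 298000 nM in an ADME assay on cells (T-cell, Mus musculus, strain BALB/c) for cytotoxicity, read by MTT assay, with a stated time of 48 h; on this read-out higher numbers stand for lower toxicity in this test and lower numbers for higher toxicity in this test. Of the two numbers in hand it is the higher, the nearest being compound 1 `COC(=O)c1ccc(C)cc1OC(=O)COc1cc(O)c2c(=O)cc(-c3ccccc3)oc2c1`, which in this assay gives 250000 nM and is within the scatter of compound 2. Among the measured compounds shown here, the only measured step, a 1.2-fold higher number from compound 1 to compound 2 (0.08 log units; within the scatter), exchanged one aryl ester for another without leaving the scatter. Compound 3 `COC(=O)c1cccc(Cl)c1OC(=O)COc1cc(O)c2c(=O)cc(-c3ccccc3)oc2c1` differs from compound 2 by a group of 11 heavy atoms (8 carbon, 2 oxygen, 1 chlorine; one six-membered aromatic ring of carbon only) in place of a group of 11 heavy atoms (9 carbon, 2 oxygen; one six-membered aromatic ring of carbon only), on an oxygen next to a carbonyl group. That step bears directly on the change expected now, so no step beyond the scatter is expected. Compound 3 is estimated at 280000 nM (range 140000 nM to 560000 nM), a step of a 1.1-fold lower number from compound 2 to compound 3 (0.03 log units; within the scatter).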

Compound 3, half-maximal cytotoxic concentration: 366000 nM
Estimate against measurement, compound 3: 1.3-fold (0.12 log units) below, within the range that was stated.
By their numbers in this assay, from the lowest: compounds 1, 2 and 3 (each within the scatter of the next).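

In this assay the entry of 2-chloro-6-(methoxycarbonyl)phenyl gives a 1.2-fold higher number from compound 2 to compound 3 (0.09 log units; within the scatter) and a 1.5-fold higher number from compound 1 to compound 3 (0.17 log units; within the scatter) on the oxygen next to a carbonyl group. Among the compounds shown here, a chlorine-bearing aryl group therefore joins the two earlier aryl groups with no step leaving the scatter, and this read-out does not separate the three at this position. No measurement at hand bears on the reason for these small steps. Still open, as far as these compounds go, is whether an amine or a carboxylic acid on this aromatic ring, or a longer chain in place of the methyl ester, would move the number beyond the scatter.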